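The source may report more compounds than this note shows. Statements on the series, on what has been measured and on what is new or still open speak of the compounds shown alone.

Compound 3 `COC(=O)c1ccc(NC(=O)Nc2cc(C)nc3ccccc23)cc1` carries a methoxycarbonyl group on the shared core of compound 1 `Cc1cc(NC(=O)Nc2ccc(F)cc2)c2ccccc2n1`, which bears fluoro, and compound 2 `Cc1cc(NC(=O)Nc2ccc(O)cc2)c2ccccc2n1`, which bears hydroxy. In an ADME assay for permeability, using PAMPA, at pH 7.4 (a lower number here means that the compound crosses the layer more slowly, a higher number that the compound crosses the layer faster), compound 1 gives 801 10^-6 cm/s, compound 2 gives 3 10^-6 cm/s and compound 3 gives 448 10^-6 cm/s. Compound 3 stands second highest of the three numbers: a 1.8-fold lower number from compound 1 to compound 3 (0.25 log units; within the scatter), whereas a 150-fold higher number from compound 2 to compound 3 (2.17 log units; beyond the scatter). Compound 4 `Cc1cc(NC(=O)Nc2ccc(Cl)cc2)c2ccccc2n1` differs from compound 3 by chloro in place of methoxycarbonyl on an aromatic carbon. The only large move seen, a 270-fold lower number from compound 1 to compound 2 (2.43 log units; beyond the scatter), involved hydroxy, which is absent here. Chloro enters with no hydrogen-bond donors or acceptors, like fluoro, and because compound 1 with fluoro gives 801 10^-6 cm/s, compound 4 is expected to change little, a 1.6-fold higher number from compound 3 to compound 4 (0.19 log units; within the scatter) within the scatter. Compound 4 is estimated at 700 10^-6 cm/s, between 300 10^-6 cm/s and 1500 10^-6 cm/s.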

Compound 4, apparent permeability: 537 10^-6 cm/s
Beside the measured number, compound 4's estimate is 1.3-fold (0.12 log units) above it, within the range that was stated.
By their numbers in this assay, from the lowest: compound 2; then compounds 3, 4 and 1 (each within the scatter of the next).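

In this assay, chloro on this aromatic carbon cannot be told apart from methoxycarbonyl (a 1.2-fold higher number from compound 3 to compound 4 (0.08 log units; within the scatter)) or from fluoro (a 1.5-fold lower number from compound 1 to compound 4 (0.17 log units; within the scatter)). Three groups that differ in size and in hydrogen-bond acceptors therefore give numbers within the scatter of one another. Hydroxy in compound 2 stands apart from a third group as well (a 180-fold higher number from compound 2 to compound 4 (2.25 log units; beyond the scatter)), so it is the one exception among the four compounds. As far as these compounds go, whether an amine or a carboxylic acid here would fall with hydroxy or with the other three stays open. Nothing at hand explains the low number of compound 2.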